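A few compounds are considered here, and "the series" means these few. Any claim that something is new, unique, unknown or untested is made for them only; others in the source may bear on it.

Three compounds have been measured in a functional assay on NCI-H23 cells (Homo sapiens) for cytotoxicity, read by sulforhodamine B assay, with a stated time of 72 h; a higher number here means a weaker inhibitor of growth, a lower number a stronger inhibitor of growth:

compound 1, `O=C(Nc1cc(C(F)(F)F)cc(C(F)(F)F)c1)C1CCc2ccccc2N1C(=O)c1ccccc1Cl`: 2080 nM
compound 2, `O=C(Nc1ccccc1O)C1CCc2ccccc2N1C(=O)c1ccccc1Cl`: 46900 nM
compound 3, `O=C(Nc1ccc(O)cc1)c1ccc2ccccc2n1`: 102000 nM

Among these three numbers, compound 3 stands highest, which in this assay means it is the weakest inhibitor of growth of the set. Its nearest neighbour is compound 2, whose number lies beyond the scatter below it, and the furthest is compound 1, whose number is far lower still. Compound 3 also differs in its core from the other two, so the comparison with them says little about any single change.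

Compound 4, `COc1ccc(NC(=O)c2ccc3ccccc3n2)cc1`, has not yet been measured. Compared with compound 3 it carries methyl in place of hydrogen on an oxygen on an aromatic ring. Within the data shown here, no pair of measured compounds shows this same change, so there is no measured step to lean on, and the change is a single carbon atom. The step from compound 3 to compound 4 is therefore expected to be small, most likely within the scatter, with a slight lean toward a higher number, a 1.1-fold higher number from compound 3 to compound 4 (0.03 log units; within the scatter). Compound 4 is expected to give about 110000 nM in this assay, with a likely range from 40000 nM to 300000 nM.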

Compound 4, concentration for 50% growth inhibition: 7650 nM
For compound 4 the middle estimate is 14-fold (1.16 log units) above the measured one; the measured number lies below the stated range.
By their numbers in this assay, from the lowest: compound 1; then compound 4; then compound 2; then compound 3.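

Replacing the hydroxy group with a methoxy group adds only one carbon, yet in this assay this change gives a 13-fold lower number from compound 3 to compound 4 (1.12 log units; beyond the scatter) and so makes growth inhibition much stronger. Among these compounds, the earlier compounds differed from one another in more than one place, so this is the first effect in the set that can be assigned to a single change, and it shows that the result is highly sensitive to what sits on this oxygen on the aromatic ring. It also shows that, for this pair, the hydrogen on that oxygen is not needed for growth inhibition, and nothing available here explains why so small a change has so large an effect.

This single pair cannot show whether the gain depends on the methyl group itself or simply on the loss of that hydrogen, and an ethoxy group, an amine or a fluorine at the same place would help to separate those two readings. Going by these compounds, compound 2 also carries a hydroxy group, on its own core, so it remains open whether a methoxy group in its place would produce a step of similar size there.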